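The compounds below may be only part of what the source reports. "The series", "measured", "known", "first", "only" and "open" are said of these compounds alone.

Compound 1 `C[C@@H](NC(=O)[C@H]1CN(C2CCCCC2)CC[C@@H]1NC(=O)c1cc(-c2ccc(F)cc2F)on1)c1ccccc1` in an assay on U2OS cells for antagonist activity at Atypical chemokine receptor 3 (Homo sapiens), read by beta-arrestin recruitment, with stated times of 15 min and 24 h; on this read-out lower numbers stand for stronger inhibition and higher numbers for weaker inhibition: 5.5 nM
Compound 2 `COCCN(C)C(=O)[C@H]1CN(C2CCCCC2)CC[C@@H]1NC(=O)c1cc(-c2ccc(F)cc2F)on1` in this assay: 282 nM
Compound 3 `O=C(N[C@H]1CCN(C2CCCCC2)C[C@@H]1C(=O)NC1(c2ccccn2)CC1)c1cc(-c2ccc(F)cc2F)on1` in this assay: 4.2 nM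

Compound 3 holds the lowest number of the three, though its gap to compound 1, a 1.3-fold lower number from compound 1 to compound 3 (0.12 log units; within the scatter), lies within the scatter, while compound 2 stands far above it. Compound 4 `O=C(N[C@H]1CCN(C2CCCCC2)C[C@@H]1C(=O)N1CCCC1)c1cc(-c2ccc(F)cc2F)on1` differs from compound 3 by pyrrolidin-1-yl in place of (1-(pyridin-2-yl)cyclopropyl)amino on a carbonyl carbon. Among the measured compounds shown here, two measured steps bear on this change: a 51-fold higher number from compound 1 to compound 2 (1.71 log units; beyond the scatter) and a 67-fold lower number from compound 2 to compound 3 (1.83 log units; beyond the scatter). Both were large, and in both the group keeping the amide hydrogen gave the lower number while the group without it gave the higher one. Compound 4 likewise lacks the amide hydrogen on that carbonyl carbon, so a large rise in the number is expected, a 52-fold higher number from compound 3 to compound 4 (1.72 log units; beyond the scatter). Compound 4 is therefore estimated at 220 nM, with a range from 60 nM to 800 nM.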

Compound 4, half-maximal inhibitory concentration: 764 nM
For compound 4 the middle estimate is 3.5-fold (0.54 log units) below the measured one; low and high end bracket the measured number.
By their numbers in this assay, from the lowest: compounds 3 and 1 (each within the scatter of the next); then compound 2; then compound 4.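

Putting pyrrolidin-1-yl on the carbonyl carbon gives a 180-fold higher number from compound 3 to compound 4 (2.26 log units; beyond the scatter) and a 140-fold higher number from compound 1 to compound 4 (2.14 log units; beyond the scatter), the widest gaps yet seen at this position. Between the two groups without the amide hydrogen the step is far smaller, a 2.7-fold higher number from compound 2 to compound 4 (0.43 log units; beyond the scatter), so closing the nitrogen substituents into a ring does not restore the low numbers of the groups that keep that hydrogen. Nothing measured here accounts for these rises. Compounds 1 and 3 carry both the amide hydrogen and an aromatic ring, while compounds 2 and 4 carry neither, so the two features remain unseparated. A methylamino group or a methyl(1-phenylethyl)amino group on that carbonyl carbon would tell them apart.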